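The source may report more compounds than this note shows. Statements on the series, on what has been measured and on what is new or still open speak of the compounds shown alone.

Measured so far:

Compound 1, `O=C(/C=C/c1cccs1)c1ccc(OCCSC(=S)N2CCCC2)cc1`: 18300 nM
Compound 2, `O=C(/C=C/c1ccc(Cl)cc1)c1ccc(OCCSC(=S)N2CCCC2)cc1`: 27800 nM
Compound 3, `O=C(/C=C/c1ccc(Cl)cc1)c1ccc(OCCCSC(=S)N2CCCCC2)cc1`: 42600 nM

All three were run in a functional assay on ECa-109 cells for inhibition, with ECa-109 cell line (Homo sapiens) as the target, read by MTT assay, with a stated time of 72 h; on this read-out lower numbers stand for stronger inhibition and higher numbers for weaker inhibition. Compound 2 and compound 3 share the 4-chlorophenyl end but differ in the other arm: a group of 10 heavy atoms (7 carbon, 1 nitrogen, 2 sulfur; one six-membered non-aromatic ring with 1 hetero atom) in place of a group of 8 heavy atoms (5 carbon, 1 nitrogen, 2 sulfur; one five-membered non-aromatic ring with 1 hetero atom), on a saturated chain carbon, two bonds along the chain from an oxygen on an aromatic ring. That change gives a 1.5-fold higher number from compound 2 to compound 3 (0.19 log units; within the scatter), so the two are not separated here. Compound 1 carries the core of compound 2 with the aryl end exchanged, (thiophen-2-yl in place of 4-chlorophenyl on a double-bonded chain carbon bound to a double-bonded chain carbon), giving a 1.5-fold lower number from compound 2 to compound 1 (0.18 log units; within the scatter), again within the scatter.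

Compound 4, `O=C(/C=C/c1cccs1)c1ccc(OCCCSC(=S)N2CCCCC2)cc1`, is not yet measured. It stands to compound 3 as compound 1 stands to compound 2: thiophen-2-yl in place of 4-chlorophenyl on a double-bonded chain carbon bound to a double-bonded chain carbon. The place lines for the two exchanges read the same word for word, so this is the same change on the other core. For the measured compounds named here, its only measured instance, compound 2 to compound 1, gave a 1.5-fold lower number from compound 2 to compound 1 (0.18 log units; within the scatter); the two cores differ by a group of 10 heavy atoms (7 carbon, 1 nitrogen, 2 sulfur; one six-membered non-aromatic ring with 1 hetero atom) in place of a group of 8 heavy atoms (5 carbon, 1 nitrogen, 2 sulfur; one five-membered non-aromatic ring with 1 hetero atom), on a saturated chain carbon, two bonds along the chain from an oxygen on an aromatic ring, which by itself moved little. The step from compound 3 to compound 4 is expected to be of like size, a 1.5-fold lower number from compound 3 to compound 4 (0.17 log units; within the scatter). Compound 4 is therefore estimated at 29000 nM, with the range 12000 nM to 70000 nM allowing for scatter.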

Compound 4, half-maximal inhibitory concentration: 36400 nM
For compound 4 the middle estimate is 1.3-fold (0.10 log units) below the measured one; low and high end bracket the measured number.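

In this assay, thiophen-2-yl in place of 4-chlorophenyl gives a 1.2-fold lower number from compound 3 to compound 4 (0.07 log units; within the scatter), so this exchange does not separate the pair on the second core either. Set beside the first instance, the exchange shows no difference in size between the two cores: the same change on two cores in this assay, a 1.5-fold lower number (0.18 log units; within the scatter) from compound 2 to compound 1 and a 1.2-fold lower number (0.07 log units; within the scatter) from compound 3 to compound 4, 1.3-fold (0.11 log units) apart, within the scatter of two such steps. This shows only that two small steps agree across the cores shown; it does not show that the exchange has a real effect on either core, or that the agreement would hold on other cores.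

Still open, on these data alone, is how the exchange behaves with other aryl ends, such as furan-2-yl or 4-methoxyphenyl, and on cores carrying a morpholine ring or a diethylamino group in place of the five-membered or six-membered non-aromatic ring. The two cores also differ in chain and ring at once, so the contribution of each remains unresolved, and a longer chain is a further open case.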